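This account rests on a few compounds, and the source may have more. Where it says the series, first, only, none or still open, it means among the compounds named here.

Working notes on the series. Compound 1 `CCOC(=O)c1c(-c2ccc(OC)cc2)[nH]c2cccc(OC)c2c1=O` carries a 4-methoxyphenyl on the shared core. In a physicochemical assay for solubility, in phosphate buffer, at pH 7.4 (a lower number here means a less soluble compound, a higher number a more soluble compound), compound 1 gives > 100000 nM, which is a limit of the assay and not a number, so compound 1 stands only at that limit, (the limit of > 100000 nM in this assay, at which 1 of the 3 values shown sits). Two further members give numbers in this assay: compound 2 `CCOC(=O)c1c(-c2ccccc2Cl)[nH]c2cc(OC)ccc2c1=O` gives 28000 nM, and compound 3 `CCOC(=O)c1c(-c2ccc(C(F)(F)F)cc2)[nH]c2cc(OC)ccc2c1=O` gives 8000 nM. Compound 4 `CCOC(=O)c1c(-c2cccc(C)c2)[nH]c2cccc(OC)c2c1=O` is not yet measured in this assay; against compound 1 it shows (3-methylphenyl in place of 4-methoxyphenyl on an aromatic carbon). Among the measured compounds shown here, no step between measured compounds is recorded, so the size of this change cannot be read from the series itself. A downward step beyond the scatter is expected, an at least 2.5-fold lower number from compound 1 to compound 4 (0.39 log units; beyond the scatter). For compound 4 the estimate in this assay is 40000 nM, with a range from 10000 nM to 150000 nM.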

Compound 4, solubility: > 100000 nM
Compound 4 ended at the assay's limit (the forecaster's own chance of this, stated with the estimate: 25%); middle value at least 2.5-fold (0.39 log units) away from the limit.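

No step from compound 1 to compound 4 can be read in this assay, as both results are limits and not numbers: the limit of > 100000 nM in this assay, at which 2 of the 4 values shown sit.

The compounds shown leave open whether 3-methylphenyl in place of 4-methoxyphenyl changes the read-out at all.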